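Replacing Trifluoromethyl with Difluoromethoxy: Expected Solubility

The source may hold more compounds than are shown below. What is called first, only, known or untested is meant among the compounds shown, and "the series" means these compounds.

In a physicochemical assay for solubility, using the shake flask method, in simulated intestinal fluid, measured as kinetic solubility, with a stated time of 2 h, at 25 degrees C, at pH 6.5 (on this read-out higher numbers stand for higher solubility and lower numbers for lower solubility), compound 1 `CCOC(=O)c1nc(C)c2c(c1N)C(=O)N(Cc1ccccc1)C2=O` gives < 5000 nM, which is a limit of the assay rather than a number. Going by the values given here, compound 2 `Cc1nc(C(=O)OC2CC2)c(N)c2c1C(=O)N(Cc1ccccc1)C2=O` gives 202000 nM in this assay, and the step of an at least 40-fold higher number from compound 1 to compound 2 (1.60 log units; beyond the scatter) is the only measured step in this set. Compound 3 `Cc1noc(-c2nc(C)c3c(c2N)C(=O)N(Cc2ccc(C(F)(F)F)cc2)C3=O)n1` gives < 5000 nM in this assay, again only a limit. Compound 3 thus stands at the limit of < 5000 nM in this assay, at which 2 of the 3 values shown sit. Compound 4 `Cc1noc(-c2nc(C)c3c(c2N)C(=O)N(Cc2ccc(OC(F)F)cc2)C3=O)n1` differs from compound 3 in one place: difluoromethoxy in place of trifluoromethyl on an aromatic carbon. Among the compounds with values here, no measured step involves a group on that aromatic ring, so the one measured step offers no direct guide here. Compound 4 is therefore expected to show no step beyond the scatter, a number no lower from compound 3 to compound 4 (the limit leaves the size open), and its solubility is estimated at 5000 nM, within 1000 nM to 20000 nM.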

Compound 4, solubility: < 5000 nM
Compound 4 was reported as a limit (the forecaster's own chance of this, stated with the estimate: 60%); the middle value sits exactly at the limit.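

Compound 3 and compound 4 both rest on a limit of the assay rather than a number, so no step between them can be read: the limit of < 5000 nM in this assay, at which 3 of the 4 values shown sit.

From the compounds shown here alone, whether difluoromethoxy in place of trifluoromethyl shifts solubility at all remains open.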